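The compounds below may be only part of what the source reports. "The series", "measured", "known", "first", "only" and "open" are said of these compounds alone.

Measured compounds:
compound 1 `C=C(c1ccccc1)c1cc2c(N)nc(-c3nc(C)cs3)nc2s1` gives > 594 nM in a functional assay on CHO-K1 cells for antagonist activity at adenosine receptor A1 (Homo sapiens), read by a beta-galactosidase reporter and cAMP accumulation, with stated times of 15 min and 6 h (on this read-out lower numbers stand for stronger inhibition and higher numbers for weaker inhibition), a limit of the assay rather than a number.
compound 2 `N#Cc1cccc(-c2nc(N)c3cc(Cc4ccccc4)sc3n2)c1` gives 222 nM.
compound 3 `CC(c1ccccc1)c1cc2c(N)nc(-c3cccc(C#N)c3)nc2s1` gives 1770 nM.

Among the compounds with values here, compound 3 thus carries the highest of the two numbers, and the only measured step, an 8.0-fold higher number from compound 2 to compound 3 (0.90 log units; beyond the scatter), leads to it. Compound 4 `C=C(c1ccccc1)c1cc2c(N)nc(-c3cccc(C#N)c3)nc2s1` differs from compound 3 by 1-phenylethenyl in place of 1-phenylethyl on an aromatic carbon. Within the data shown here, no measured step covers this change; the measured step concerns a different group, so it gives no direct guide. Compound 1, which carries the same 1-phenylethenyl group, reached only a limit, (the limit of > 594 nM in this assay, at which 1 of the 3 values shown sits). Compound 4 is therefore expected to remain weak, with an estimated 1.2-fold lower number from compound 3 to compound 4 (0.07 log units; within the scatter). The estimate for compound 4 in this assay is 1500 nM, spanning 400 nM to 6000 nM.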

Compound 4, inhibition constant: > 1000 nM
Compound 4: a limit, no number (the forecaster's own chance of this, stated with the estimate: 45%); the middle value does not contradict the limit.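

In this assay, 1-phenylethenyl in place of benzyl on an aromatic carbon next to the ring sulfur gives an at least 4.5-fold higher number from compound 2 to compound 4 (0.65 log units; beyond the scatter), so a higher number than that of the benzyl compound now appears with a second group at this position, not only with 1-phenylethyl. Compound 4 itself reaches only a limit: the limit of > 1000 nM in this assay, at which 1 of the 4 values shown sits. The steps to compound 4 from compound 3 and from compound 1 cannot be read, so the change from 1-phenylethyl to 1-phenylethenyl has no measurable size here. Going by these compounds, how the two groups rank against each other stays open. So does how an amine or a longer chain at this position would read.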